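This account rests on a few compounds, and the source may have more. Where it says the series, first, only, none or still open, it means among the compounds named here.

Values in an ADME assay (liver) for metabolic stability, with Liver microsome (Rattus norvegicus) as the target, using microsomes and NADPH, with a stated time of 30 min, tested at 1 uM; a higher number here means faster removal of the compound, a lower number slower removal:
- compound 1 `Nc1ccc(S(=O)(=O)N2CCN(c3ncc(C(O)(C(F)(F)F)C(F)(F)F)cc3C#CCCO)CC2)cn1`: 68 mL.min-1.g-1
- compound 2 `CS(=O)(=O)c1ccc(-c2cc(C(O)(C(F)(F)F)C(F)(F)F)cnc2N2CCN(S(=O)(=O)c3ccc(N)nc3)CC2)cc1`: 103 mL.min-1.g-1
- compound 3 `Nc1ccc(S(=O)(=O)N2CCN(c3ncc(C(O)(C(F)(F)F)C(F)(F)F)cc3-c3cncc(F)c3)CC2)cn1`: 19 mL.min-1.g-1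

Of the three, compound 3 gives the lowest number, 19 mL.min-1.g-1. Next is compound 4 `Nc1ccc(S(=O)(=O)N2CCN(c3ncc(C(O)(C(F)(F)F)C(F)(F)F)cc3-c3ccc4ocnc4c3)CC2)cn1`, not yet measured, with 1,3-benzoxazol-5-yl in place of 5-fluoropyridin-3-yl on an aromatic carbon.

Two measured steps end at the group that leaves here: a 3.6-fold lower number from compound 1 to compound 3 (0.55 log units; beyond the scatter) and a 5.4-fold lower number from compound 2 to compound 3 (0.73 log units; beyond the scatter). The remaining step, a 1.5-fold higher number from compound 1 to compound 2 (0.18 log units; within the scatter), involves two other groups at the same place. So both other groups measured there stand higher than 5-fluoropyridin-3-yl, though only compound 1 and compound 2 support this. Within the data shown here, no measured compound carries 1,3-benzoxazol-5-yl, so the size of the step rests on those two comparisons alone.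

A modest rise is expected, of about the size seen in those steps, stated as an estimated 2.4-fold higher number from compound 3 to compound 4 (0.37 log units; beyond the scatter). For compound 4 the estimated value is 45 mL.min-1.g-1, with an expected range of 18 mL.min-1.g-1 to 110 mL.min-1.g-1.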

Compound 4, intrinsic clearance in microsomes: 120 mL.min-1.g-1
Beside the measured number, compound 4's estimate is 2.7-fold (0.43 log units) below it; measured number outside the range, above it.
By their numbers in this assay, from the lowest: compound 3; then compounds 1, 2 and 4 (each within the scatter of the next).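

In this assay, among these compounds, 5-fluoropyridin-3-yl is so far the only group at this position that stands apart, and a second aromatic group does not share its low number (a 6.3-fold higher number from compound 3 to compound 4 (0.80 log units; beyond the scatter)). 1,3-Benzoxazol-5-yl does not separate from the other two groups (a 1.2-fold higher number from compound 2 to compound 4 (0.07 log units; within the scatter); a 1.8-fold higher number from compound 1 to compound 4 (0.25 log units; within the scatter)), so compound 1, compound 2 and compound 4 form one level, despite the alkynyl chain of compound 1 and the different aromatic groups of compound 2 and compound 4. No measurement of any property of these groups accompanies the numbers, so the gap to compound 3 stays unexplained.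

Open, going by these compounds, is whether the low number of compound 3 goes with the ring nitrogen, the fluorine or both. A plain pyridin-3-yl or a 3-fluorophenyl group at this position would separate the two.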